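Extending the Amine Side Chain of Compound 1

The source may report more compounds than this note shows. Statements on the series, on what has been measured and on what is new or still open speak of the compounds shown alone.

Measured so far:
Compound 1, `OC1Cc2ccccc2CCC1NCCCc1ccccc1`: 100 nM
Compound 2, `OC1c2ccccc2CCC(NCCCc2ccccc2)C1O`: 630 nM

Both numbers come from an assay on membranes from liver for displacement of a labelled ligand from Sigma intracellular receptor 2 (Rattus norvegicus), read by scintillation counting, with a stated time of 120 min; a higher number here means a weaker inhibitor, a lower number a stronger inhibitor. Going by the values given here, compound 1 stands lowest of the two, and the only measured step, a 6.3-fold higher number from compound 1 to compound 2 (0.80 log units; beyond the scatter), concerns hydroxy in place of hydrogen on a saturated ring carbon, a change on the core rather than on the side chain.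

Compound 3, `OC1Cc2ccccc2CCC1NCCCCc1ccccc1`, has not yet been measured. It differs from compound 1 by benzyl in place of phenyl on a saturated chain carbon, three bonds along the chain from an amine nitrogen. Among the compounds with values here, no measured pair alters this part of the molecule, so the one known step does not bear on the change and offers no direction for it.

Without a guiding step, the expectation is a number close to that of compound 1, a step estimated at a 1.3-fold lower number from compound 1 to compound 3 (0.10 log units; within the scatter). The estimate for compound 3 in this assay is therefore 80 nM, expected to fall between 25 nM and 320 nM.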

Compound 3, inhibition constant: 100 nM
For compound 3 the middle estimate is 1.3-fold (0.10 log units) below the measured one, within the range that was stated.
By their numbers in this assay, from the lowest: compounds 1 and 3 (each within the scatter of the next); then compound 2.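

Going by these compounds alone, replacing phenyl with benzyl on a saturated chain carbon, three bonds along the chain from an amine nitrogen, is the first measured change to the side chain, and in this assay it gives no change at the digits printed from compound 1 to compound 3 (within the scatter). Within the data shown here, this shows that, for this pair, the larger benzyl group is tolerated at this position with no difference beyond the scatter, whereas the only earlier step, a 6.3-fold higher number from compound 1 to compound 2 (0.80 log units; beyond the scatter), was a change on the core. No measurement shown explains why compound 1 and compound 3 read alike.

From the compounds shown here alone, whether a longer chain, or a carboxylic acid in place of the benzyl, would also leave the number within the scatter remains open. Going by these compounds, it is also open whether the hydroxy change on the core would have the same effect on compound 3.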